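Working notes on the step from compound 2 to compound 3

The source may hold more compounds than are shown below. What is called first, only, known or untested is meant among the compounds shown, and "the series" means these compounds.

Of the compounds shown here, two have been read in an assay for inhibition of Nicotinamide phosphoribosyltransferase (Mus musculus), read by fluorescence, with a stated time of 1 h, in the presence of a further agent that is not named here; a higher number here means a weaker inhibitor, a lower number a stronger inhibitor. Compound 1 `O=C(NCCCCCCCn1cc(-c2ccc[n+]([O-])c2)nn1)c1ccccc1-c1ccccc1` gives only a limit in this assay, namely > 500 nM. Among the compounds with values here, compound 2 `NC(=O)c1ccccc1-c1ccccc1C(=O)NCCCCCCCn1cc(-c2cccnc2)nn1` gives 87.9 nM in this assay, the single numerical value so far; the other entry is the limit of > 500 nM in this assay, at which 1 of the 2 values shown sits. Within the data shown here, compound 2 therefore stands alone as the one compound with a measured number, and no ranking can be drawn from it.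

Compound 3 `O=C(O)c1ccc(-c2ccccc2C(=O)NCCCCCCCn2cc(-c3cccnc3)nn2)cc1` is not yet measured. It differs from compound 2 by 4-carboxyphenyl in place of 2-carbamoylphenyl on an aromatic carbon. Among the measured compounds shown here, no step between two measured compounds is available, so the size of this change rests on expectation alone. Compound 3 is expected to give 220 nM in this assay, within 50 nM to 900 nM. This corresponds to an expected step of a 2.5-fold higher number from compound 2 to compound 3 (0.40 log units; beyond the scatter), a weakening modestly beyond the scatter, though a value within the scatter of compound 2 would not be surprising.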

Compound 3, half-maximal inhibitory concentration: > 500 nM
Compound 3: no number, only a limit; the forecaster's own chance of this, stated with the estimate: 25%; middle value at least 2.2-fold (0.35 log units) from the limit.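

In this assay, placing 4-carboxyphenyl in place of 2-carbamoylphenyl on this aromatic carbon, ortho to a large group, gives an at least 5.6-fold higher number from compound 2 to compound 3 (0.75 log units; beyond the scatter), so the position is sensitive to this exchange. Compound 3 gives only a limit, which means the step has a lower bound and no measured size. The series still holds a single numerical value, that of compound 2, and the remaining entries share one limit: the limit of > 500 nM in this assay, at which 2 of the 3 values shown sit.

The compounds shown do not separate the effect of exchanging the carbamoyl group for a carboxylic acid from that of moving the substituent on the phenyl ring. From the compounds shown here alone, a 2-carboxyphenyl or a 4-carbamoylphenyl group at this position would bear on that question, and how far the reading of compound 3 lies past its limit remains open.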